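Chloro to Methoxy on the Hydroxy-Bearing Ring

The compounds below may be only part of what the source reports. "The series", "measured", "known", "first", "only" and "open" are said of these compounds alone.

Compound 1 `COc1ccc(/C=C2\CCC/C(=C\c3cccc(Cl)c3)C2=O)cc1OC` gives 11000 nM in a functional assay on A549 cells (Homo sapiens) for cytotoxicity, read by MTT assay, with a stated time of 72 h; a lower number here means a stronger inhibitor, a higher number a weaker inhibitor. Compound 2 `COc1cccc(/C=C2\CCC/C(=C\c3ccc(OC)c(OC)c3)C2=O)c1` gives 6700 nM in this assay. For compound 3 `COc1ccc(/C=C2\CCC/C(=C\c3ccc(O)c(Cl)c3)C2=O)cc1OC` this assay returns only a limit, > 20000 nM (the limit of > 20000 nM in this assay, at which 1 of the 3 values shown sits). Compound 4 `COc1cc(/C=C2\CCC/C(=C\c3ccc(OC)c(OC)c3)C2=O)ccc1O` is not yet measured.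

Methoxy in place of chloro, (methoxy in place of chloro on an aromatic carbon), produced a 1.6-fold lower number from compound 1 to compound 2 (0.22 log units; within the scatter). The same kind of change leads from compound 3 to compound 4, (methoxy in place of chloro on an aromatic carbon), but here the place is also ortho to a hydroxy group (1 heavy atom), so the surroundings differ. The two cores differ by hydroxy in place of hydrogen on an aromatic carbon, which gave an at least 1.8-fold higher number from compound 1 to compound 3 (0.25 log units; that floor lies within the scatter). The step expected here is a number no higher from compound 3 to compound 4 (the limit leaves the size open), judged small from the earlier methoxy-for-chloro step. The starting point is the limit read for compound 3. Compound 4 is therefore estimated at 20000 nM, likely between 8000 nM and 50000 nM, with a real chance that only a limit is reported again.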

Compound 4, half-maximal inhibitory concentration: 10300 nM
Estimate against measurement, compound 4: 1.9-fold (0.29 log units) above; the measured number falls inside the stated range.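

Whether methoxy in place of chloro keeps its size from one core to the other in this assay stays unsettled: the same change on two cores in this assay, a 1.6-fold lower number (0.22 log units; within the scatter) from compound 1 to compound 2 and an at least 1.9-fold lower number (0.28 log units; that floor lies within the scatter) from compound 3 to compound 4; the limit leaves it open whether they differ

Hydroxy in place of hydrogen stands the same way: the same change on two cores in this assay, an at least 1.8-fold higher number (0.25 log units; that floor lies within the scatter) from compound 1 to compound 3 and a 1.5-fold higher number (0.19 log units; within the scatter) from compound 2 to compound 4; the limit leaves it open whether they differ

The data give an at least 1.9-fold lower number from compound 3 to compound 4 (0.28 log units; that floor lies within the scatter), which is only a floor, along with a 1.5-fold higher number from compound 2 to compound 4 (0.19 log units; within the scatter) and a 1.1-fold lower number from compound 1 to compound 4 (0.03 log units; within the scatter), so no order can be drawn among compound 1, compound 2 and compound 4.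

On these data alone, the true position of compound 3 remains open, since its reading is a limit. Also open, as far as these compounds go, is how this assay responds when an amine or a carboxylic acid stands in place of the chloro or methoxy group.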